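This account rests on a few compounds, and the source may have more. Where it says the series, first, only, none or still open, it means among the compounds named here.

Working notes on the series in a functional assay on UO-31 cells (Homo sapiens) for cytotoxicity, read by sulforhodamine B assay, with a stated time of 48 h; on this read-out lower numbers stand for stronger inhibition of growth and higher numbers for weaker inhibition of growth. Compound 1 `ClCc1ccc(Cn2cnc3c(Cl)ncnc32)cc1` gives 2080 nM; compound 2 `ClCc1cccc(Cn2cnc3ncnc(Cl)c32)c1` gives 1540 nM. Of the two numbers shown, compound 1 carries the higher one, but the gap to compound 2 is within the scatter, so the two stand together. Compound 3 `ClCc1ccc(Cn2cnc3c(Cl)nc(Cl)nc32)cc1` differs from compound 1 by chloro in place of hydrogen on an aromatic carbon. Among the compounds with values here, no measured pair shows this kind of change, so only a small step is expected, with a slight lean toward a lower number and probably none beyond the scatter. The expected step is a 1.4-fold lower number from compound 1 to compound 3 (0.14 log units; within the scatter). Compound 3 is estimated at 1500 nM, within a range of 500 nM to 4500 nM.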

Compound 3, concentration for 50% growth inhibition: 19500 nM
The estimate for compound 3 lay 13-fold (1.11 log units) below the measured number, outside the stated range (above it).
By their numbers in this assay, from the lowest: compounds 2 and 1 (each within the scatter of the next); then compound 3.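

Chloro in place of hydrogen on this aromatic carbon, between two ring nitrogen atoms, is not a silent change in this assay, with a 9.4-fold higher number from compound 1 to compound 3 (0.97 log units; beyond the scatter). This single added heavy atom thus weakens growth inhibition, a sensitivity at this position that the earlier pair could not show. No measurement at hand gives a reason for the step.

As far as these compounds go, whether the weakening belongs to chloro itself or to any replacement of hydrogen here stays open. An amine or a methyl group on the same carbon would help separate the two.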